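This account rests on a few compounds, and the source may have more. Where it says the series, first, only, none or still open, it means among the compounds named here.

Compound 1, with the structure `Cc1cc(O)c(C(=O)/C=C/c2ccc(Cl)cc2)c(-c2ccccc2)c1C(=O)/C=C/c1ccc(Cl)cc1`, carries two chloro-substituted arms and a plain phenyl on the shared core. In a functional assay on MDA-MB-231 cells (Homo sapiens) for cytotoxicity, read by MTT assay, with a stated time of 24 h (a higher number here means a weaker inhibitor, a lower number a stronger inhibitor), compound 1 gives 7900 nM. Compound 2, with the structure `COc1ccc(/C=C/C(=O)c2c(C)cc(O)c(C(=O)/C=C/c3ccc(OC)cc3)c2-c2ccccc2)cc1`, keeps the same core but has methoxy groups in place of the chloro atoms; in this assay compound 2 is reported as "not active" (no number reported). Compound 3, with the structure `COc1ccc(/C=C/C(=O)c2c(C)cc(O)c(C(=O)/C=C/c3ccc(OC)cc3)c2-c2ccc(Br)cc2)cc1`, differs from compound 2 only in a bromo on the pendant phenyl ring, and in this assay compound 3 is again reported as "not active" (no number reported). Compound 3 therefore stands without a number, alongside one further entry that likewise carries no number, so its position among the compounds cannot be placed on a scale.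

Compound 4, with the structure `COc1ccc(/C=C/C(=O)c2c(C)cc(O)c(C(=O)/C=C/c3ccc(OC)cc3)c2-c2ccc(OCc3ccccc3)cc2)cc1`, follows from compound 3 by one change: benzyloxy in place of bromo on an aromatic carbon. Among the compounds with values here, no step between measured compounds covers such a change, and the two methoxy-bearing compounds both lacked a number, so no shift beyond the scatter in this assay can be supported by the data. Compound 4 is expected to give about 30000 nM, within a range from 8000 nM to 100000 nM.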

Compound 4, half-maximal inhibitory concentration: 12000 nM
For compound 4 the middle estimate is 2.5-fold (0.40 log units) above the measured one; low and high end bracket the measured number.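

In this assay, within the data shown here, compound 4 gives 12000 nM and compound 3 has no number, so no step between them can be read. What benzyloxy in place of bromo does to the value stays open, and nothing measured here offers an explanation for the result.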